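The source may report more compounds than this note shows. Statements on the series, on what has been measured and on what is new or still open speak of the compounds shown alone.

In a functional assay on MGC-803 cells (Homo sapiens) for antiproliferative activity, read by CellTiter-Glo, with a stated time of 72 h (a higher number here means a weaker inhibitor, a lower number a stronger inhibitor), the measured compounds read as follows
compound 1 `O=C(NO)c1cccc(/C=C/c2ccnc(-c3ccccc3O)c2)c1` gives 2810 nM in this assay
compound 2 `O=C(NO)c1ccc(/C=C/c2ccnc(-c3cccnc3)c2)cc1` gives 4550 nM in this assay
compound 3 `Cc1ccc(-c2cc(/C=C/c3ccc(C(=O)NO)cc3)c(F)cn2)c(F)c1` gives 2510 nM in this assay

Compound 2 lies within the usual scatter of both compound 1 and compound 3, so its value sets no order among them. Going by the values given here, these three compounds differ from one another in more than one place, and no step at a single place has been measured.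

Compound 4 `O=C(NO)c1ccc(/C=C/c2ccnc(Br)c2)cc1` keeps the rest of compound 2 but carries bromo in place of pyridin-3-yl on an aromatic carbon, a change counted as bromo in place of pyridin-3-yl on an aromatic carbon here. Among the compounds with values here, no measured pair shows what such an exchange does in this assay, so no step beyond the scatter is expected, in either direction. The only ground for this expectation is that compound 1 at 2810 nM and compound 3 at 2510 nM stay close to compound 2 at 4550 nM despite their different structures. Within the data shown here, no measured compound lacks a ring at this place, so the expected range is kept wide.

The estimated step is a 1.1-fold lower number from compound 2 to compound 4 (0.06 log units; within the scatter), which is expected to stay within the scatter. For compound 4 the estimated half-maximal inhibitory concentration is 4000 nM, with an expected range from 1300 nM to 12000 nM.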

Compound 4, half-maximal inhibitory concentration: > 10000 nM
Compound 4 gave a limit, no number; the forecaster's own chance of this, stated with the estimate: 8%; middle value at least 2.5-fold (0.39 log units) from the limit.
By their numbers in this assay, from the lowest: compounds 3, 1 and 2 (each within the scatter of the next). At a limit, above all of these: compound 4.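

In this assay, going by these compounds alone, the exchange of pyridin-3-yl for bromo, on an aromatic carbon next to the ring nitrogen, gives an at least 2.1-fold higher number from compound 2 to compound 4 (0.34 log units; beyond the scatter) and is the first step at a single place measured here. Compounds 1, 2 and 3 all carry a ring at this place, so their close values could not show what happens without one; compound 4 shows that a single bromo here does not keep the activity of compound 2. Compound 4 gave a limit and not a number, so the step is a minimum and its full size stays unknown: the limit of > 10000 nM in this assay, at which 1 of the 4 values shown sits.

The compounds shown leave open whether a small group other than bromo, such as an amine, a methoxy group or a short alkyl chain, would fare any better at this place, or whether a ring is what this position needs. They also leave open what a plain phenyl ring would do here in the frame of compound 2, as compounds 1 and 3 differ from compound 2 in more than one place.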